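Amide to acid on a second core: expected gain

The source may report more compounds than this note shows. Statements on the series, on what has been measured and on what is new or still open speak of the compounds shown alone.

Compound 1 `CNC(=O)/C=C/c1ccncc1-c1ccc2ccccc2c1` and compound 2 `O=C(O)/C=C/c1ccncc1-c1ccc2ccccc2c1` share one core and differ only at the chain end. In an assay on a protein complex for inhibition of CDK8/Cyclin C (Homo sapiens), with a stated time of 1 h (on this read-out higher numbers stand for weaker inhibition and lower numbers for stronger inhibition), compound 1 gives 12.4 nM, and compound 2 gives 5 nM. The change between them is hydroxy in place of methylamino on a carbonyl carbon and the step is a 2.5-fold lower number from compound 1 to compound 2 (0.39 log units; beyond the scatter).

Going by the values given here, compound 3 `CNC(=O)/C=C/c1ccncc1-c1ccc2[nH]ccc2c1` carries a different core with the same chain as compound 1; in this assay compound 3 gives 51.9 nM, the highest of the three numbers so far. The difference between the two cores is not broken down here. Compound 4 `O=C(O)/C=C/c1ccncc1-c1ccc2[nH]ccc2c1` is the not yet measured partner of compound 3; its difference from compound 3 is hydroxy in place of methylamino on a carbonyl carbon. Among the compounds with values here, the place of the change, a carbonyl carbon whose other neighbour is a double-bonded chain carbon, is the same in both pairs, so this is the same change as the one from compound 1 to compound 2, seen on the other core.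

Within the data shown here, the only reference is the single step from compound 1 to compound 2, so the expectation rests on one observation and the two cores may not respond alike. Still, compound 4 is expected to sit lower than compound 3 in this assay by about a 2.5-fold lower number from compound 3 to compound 4 (0.39 log units; beyond the scatter), because the matching change gave a 2.5-fold lower number from compound 1 to compound 2 (0.39 log units; beyond the scatter). The estimate for compound 4 in this assay is 21 nM, with a plausible range of 10 nM to 45 nM.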

Compound 4, half-maximal inhibitory concentration: 17 nM
Compound 4: the middle estimate sits 1.2-fold (0.09 log units) above what was measured; the measured number falls inside the stated range.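

In this assay, replacing methylcarbamoyl with carboxy on the core of compound 3 gives a 3.1-fold lower number from compound 3 to compound 4 (0.48 log units; beyond the scatter), in the same direction as the step on the core of compound 1, and the two steps do not differ beyond what repeated measurements would allow: the same change on two cores in this assay, a 2.5-fold lower number (0.39 log units; beyond the scatter) from compound 1 to compound 2 and a 3.1-fold lower number (0.48 log units; beyond the scatter) from compound 3 to compound 4, 1.2-fold (0.09 log units) apart, within the scatter of two such steps

Within these two pairs, then, the change carries from one core to the other in both direction and size, and no dependence on the core can be seen. This rests on two pairs and one read-out, so it does not establish that the step would hold on any further core, and it says nothing about why the acid gives the lower number on either core.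

Still open, on these data alone, is how other chain ends would compare with the carboxy and methylcarbamoyl pair, for example a primary amide, a methyl ester, a hydroxamic acid or a tetrazole. Also open, as far as these compounds go, is whether the step survives a longer chain, or a saturated ethyl link in place of the ethenyl, and whether it holds on a third core.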